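The compounds below may be only part of what the source reports. "The series", "measured", "known", "first", "only" and "open" are said of these compounds alone.

Compound 1 `O=c1[nH]c(=O)n(COCCO)cc1[N+](=O)[O-]` is the reference point of the series. In a functional assay on Vero cells (Chlorocebus sabaeus) for cytotoxicity, read by MTT assay (a higher number here means that more compound is tolerated, a lower number that less compound is tolerated), compound 1 gives > 432000 nM, which is a limit of the assay and not a number. Compound 2 `Nc1cn(COCCO)c(=O)[nH]c1=O` carries amino in place of nitro on an aromatic carbon. In this assay compound 2 gives > 497000 nM, again a limit. Compound 3 `O=c1[nH]c(=O)n(COCCO)cc1CO` carries hydroxymethyl in place of nitro on an aromatic carbon. In this assay compound 3 gives > 476000 nM, also a limit. The three measured steps, a step that the two limits leave unreadable from compound 1 to compound 2, a step that the two limits leave unreadable from compound 1 to compound 3 and a step that the two limits leave unreadable from compound 2 to compound 3, therefore have no readable size: every value sits at a limit, (the limit of > 432000 nM in this assay, at which 1 of the 3 values shown sits), the limit of > 476000 nM in this assay, at which 1 of the 3 values shown sits, and (the limit of > 497000 nM in this assay, at which 1 of the 3 values shown sits).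

Compound 4 `Cc1c([N+](=O)[O-])c(=O)[nH]c(=O)n1COCCO` differs from compound 1 by methyl in place of hydrogen on an aromatic carbon. Going by the values given here, none of the measured steps concerns this change, and none gives a size that could be carried over; what they do show is that every substituent tried so far at the other position left the compound tolerated up to the highest concentration tested. The expectation is that compound 4 behaves the same way, so the estimated step is a step that the limit leaves unreadable from compound 1 to compound 4, in no direction beyond the scatter. Compound 4 is expected to give 450000 nM in this assay, with a range from 200000 nM to 1500000 nM.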

Compound 4, half-maximal cytotoxic concentration: > 408000 nM
Compound 4 gave a limit, no number; the forecaster's own chance of this, stated with the estimate: 85%; the middle value is on the limit's open side.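

In this assay compound 4 gives > 408000 nM, which is a limit of the assay and not a number. Compound 1 also stands at a limit, so no step can be read between compound 1 and compound 4. The compounds shown leave open at what concentration, if any, cytotoxicity appears, and whether methyl in place of hydrogen alters it.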